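The compounds below may be only part of what the source reports. "The series", "measured", "known", "first", "only" and "open" are said of these compounds alone.

Compound 3 `N#Cc1cccc(Cn2c(=O)n(C3OC(CO)[C@@H](O)[C@H]3O)c3nc(N)nc(O)c32)c1` stands lowest of the three compounds measured in a functional assay on the whole organism (B cells) with Mus musculus as the target; on this read-out lower numbers stand for smaller maximal responses and higher numbers for larger maximal responses: compound 3 reaches 16%, whereas compound 1 `Nc1nc(O)c2c(n1)n(C1OC(CO)[C@@H](O)[C@H]1O)c(=O)n2Cc1ccc(Cl)c(Cl)c1` reaches 55% and compound 2 `Nc1nc(O)c2c(n1)n(C1OC(CO)[C@@H](O)[C@H]1O)c(=O)n2CC(O)CO` reaches 136%. Both gaps lie beyond the scatter, as a number 39 percentage points lower from compound 1 to compound 3 (beyond the scatter) and a number 120 percentage points lower from compound 2 to compound 3 (beyond the scatter) show.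

Compound 4 `N#Cc1ccc(Cn2c(=O)n(C3OC(CO)[C@@H](O)[C@H]3O)c3nc(N)nc(O)c32)cc1` differs from compound 3 in one place: 4-cyanophenyl in place of 3-cyanophenyl on a saturated chain carbon bound to an aromatic nitrogen. The measured steps all bear on this place, since each exchanges the group on a saturated chain carbon bound to an aromatic nitrogen, and each was large: a number 81 percentage points higher from compound 1 to compound 2 (beyond the scatter), a number 39 percentage points lower from compound 1 to compound 3 (beyond the scatter) and a number 120 percentage points lower from compound 2 to compound 3 (beyond the scatter). Yet every one of them swaps a whole group for a different one, while the change to compound 4 merely moves a nitrile within the same ring. Within the data shown here, no measured pair shows what such a move does, so only a modest step is expected for compound 4, in either direction, likely within the scatter: a number 6 percentage points higher from compound 3 to compound 4 (within the scatter). Compound 4 is therefore estimated at 22%, with a range from 5% to 55%.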

Compound 4, largest response reached (reported as maximal response), in percent of the reference or control that the assay uses: 50%
Beside the measured number, compound 4's estimate is 28 percentage points below it; the measured number falls inside the stated range.
By their numbers in this assay, from the lowest: compound 3; then compounds 4 and 1 (each within the scatter of the next); then compound 2.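

Moving the nitrile alone proves to matter at this position: in this assay, 4-cyanophenyl in place of 3-cyanophenyl on a saturated chain carbon bound to an aromatic nitrogen gives a number 34 percentage points higher from compound 3 to compound 4 (beyond the scatter), a large step from a change that keeps the same atoms. The 4-cyanophenyl and 3,4-dichlorophenyl groups read alike, with a number 5 percentage points lower from compound 1 to compound 4 (within the scatter), while 1,2-dihydroxyethyl stays well apart, with a number 86 percentage points lower from compound 2 to compound 4 (beyond the scatter), so among the three aromatic groups 3-cyanophenyl alone stands apart. Nothing available explains why the place of the nitrile on the ring has this effect.

From the compounds shown here alone, whether a carboxylic acid or an amine in place of the nitrile would depend in the same way on where it sits on the ring remains open. Also open, going by these compounds, is whether a longer chain carrying hydroxyl groups would keep the large response of compound 2.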